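Moving the Fluorine Around the Urea Aryl Ring

This account rests on a few compounds, and the source may have more. Where it says the series, first, only, none or still open, it means among the compounds named here.

Of the compounds shown here, three sharing one core have been measured in a functional assay on HT-29 cells (Homo sapiens) for cytotoxicity, read by MTT assay, with a stated time of 72 h; a lower number here means a stronger inhibitor, a higher number a weaker inhibitor. Compound 1 `CN(C)CCNc1nc(-c2ccc(NC(=O)Nc3ccc(F)cc3)cc2)nc2ccsc12` gives 350 nM, and compound 2 `CN(C)CCNc1nc(-c2ccc(NC(=O)Nc3ccccc3F)cc2)nc2ccsc12` gives 510 nM. The two differ only by 2-fluorophenyl in place of 4-fluorophenyl on an amide-type nitrogen, and this change gave a 1.5-fold higher number from compound 1 to compound 2 (0.16 log units; within the scatter). Compound 3 `CCN(CC)CCCNc1nc(-c2ccc(NC(=O)Nc3ccc(F)cc3)cc2)nc2ccsc12` gives 340 nM; it differs from compound 1 by (diethylamino)methyl in place of dimethylamino on a saturated chain carbon, two bonds along the chain from a nitrogen on an aromatic ring, which gave a 1.0-fold lower number from compound 1 to compound 3 (0.01 log units; within the scatter).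

Compound 4 `CCN(CC)CCCNc1nc(-c2ccc(NC(=O)Nc3ccccc3F)cc2)nc2ccsc12` has not yet been measured. It differs from compound 3 by 2-fluorophenyl in place of 4-fluorophenyl on an amide-type nitrogen. Among the measured compounds shown here, this is the same change that turned compound 1 into compound 2, and the place where it happens is described in the same words for both pairs, so the change is of the same kind and the earlier pair is the only guide available. On that basis compound 4 is expected to show a 1.5-fold higher number from compound 3 to compound 4 (0.17 log units; within the scatter), because the comparable move gave a 1.5-fold higher number from compound 1 to compound 2 (0.16 log units; within the scatter), a step that stays within the usual scatter. Compound 4 is therefore estimated at 500 nM, with a plausible range from 250 nM to 1000 nM.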

Compound 4, half-maximal inhibitory concentration: 550 nM
Compound 4: middle estimate off by 1.1-fold (0.04 log units), on the low side; measured number inside the range.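

Replacing 4-fluorophenyl with 2-fluorophenyl on the amide-type nitrogen gives a 1.6-fold higher number from compound 3 to compound 4 (0.21 log units; within the scatter) in this assay, and this step agrees with the one seen earlier on the core of compound 1: the same change on two cores in this assay, a 1.5-fold higher number (0.16 log units; within the scatter) from compound 1 to compound 2 and a 1.6-fold higher number (0.21 log units; within the scatter) from compound 3 to compound 4, 1.1-fold (0.05 log units) apart, within the scatter of two such steps. The swap of dimethylamino for (diethylamino)methyl also behaves alike on both partners, giving a 1.1-fold higher number from compound 2 to compound 4 (0.03 log units; within the scatter): the same change on two cores in this assay, a 1.0-fold lower number (0.01 log units; within the scatter) from compound 1 to compound 3 and a 1.1-fold higher number (0.03 log units; within the scatter) from compound 2 to compound 4, 1.1-fold (0.05 log units) apart, within the scatter of two such steps. Each change therefore carries from one core to the other in these four compounds, but every step stays within the scatter, so what carries over is the absence of a measurable shift, and the data do not show that either change affects the result or that a larger effect would transfer in the same way.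

Still open, going by these compounds, is whether a different group on the amide-type nitrogen, such as 3-fluorophenyl or 4-chlorophenyl, would give a step beyond the scatter. The same question applies to a piperidine or a morpholine in place of the dimethylamino group.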